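Selenoquinoline esters: methoxy to chloro on the quinoline

The source may hold more compounds than are shown below. What is called first, only, known or untested is meant among the compounds shown, and "the series" means these compounds.

Measured compounds:
compound 1, `CCOC(=O)c1cc([Se]Cc2ccccc2)c2cc(OC)ccc2n1`, 20800 nM
compound 2, `CCOC(=O)c1cc([Se]c2ccc3cc(OC)ccc3c2)c2cc(OC)ccc2n1`, 31300 nM
compound 3, `CCOC(=O)c1cc([Se]Cc2ccccc2)c2cc(Cl)ccc2n1`, 88500 nM

Three selenium-bearing esters have been tested in a functional assay on Jurkat cells (Homo sapiens) for cytotoxicity, read by MTT assay, with a stated time of 24 h; a higher number here means that more compound is needed for the effect, a lower number that less compound is needed. Compound 1 and compound 3 share a core and differ in one place: chloro in place of methoxy on an aromatic carbon. That change gave a 4.3-fold higher number from compound 1 to compound 3 (0.63 log units; beyond the scatter). Compound 2 carries a different selenium substituent; how its core differs from the core of compound 1 is not broken down here. In this assay compound 2 gives a number close to that of compound 1, and the two lie within the usual scatter of each other, while compound 3 sits beyond the scatter from both.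

Compound 4, `CCOC(=O)c1cc([Se]c2ccc3cc(OC)ccc3c2)c2cc(Cl)ccc2n1`, is not yet measured. It stands to compound 2 as compound 3 stands to compound 1: chloro in place of methoxy on an aromatic carbon. Because the same change gave a 4.3-fold higher number from compound 1 to compound 3 (0.63 log units; beyond the scatter), a step of similar size is expected here, resting on that single earlier pair alone. Compound 4 is therefore expected to show a 4.2-fold higher number from compound 2 to compound 4 (0.62 log units; beyond the scatter) in this assay. The estimate for compound 4 in this assay is 130000 nM, with a range from 55000 nM to 300000 nM.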

Compound 4, half-maximal effective concentration: 29200 nM
For compound 4 the middle estimate is 4.5-fold (0.65 log units) above the measured one; the measured number lies below the stated range.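

Chloro in place of methoxy gave a 1.1-fold lower number from compound 2 to compound 4 (0.03 log units; within the scatter) in this assay, so compound 2 and compound 4 lie within the scatter of each other. Set beside the earlier pair, the same change did not carry over in size from one core to the other: the same change on two cores in this assay, a 4.3-fold higher number (0.63 log units; beyond the scatter) from compound 1 to compound 3 and a 1.1-fold lower number (0.03 log units; within the scatter) from compound 2 to compound 4, 4.6-fold (0.66 log units) apart, beyond the scatter of two such steps. This shows that, in these two pairs, the step seen on one core could not be read across to the other, but two pairs alone do not show which difference between the cores is responsible, nor what the change would do on any further core.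

The compounds shown leave open whether another group in place of the methoxy, such as fluoro or an amine, would follow the step to compound 3 or the step to compound 4. They also leave open how a carboxylic acid in place of the ethyl ester would read on either core.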